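Dienone series: furan-3-yl in place of 4-bromophenyl

A few compounds are considered here, and "the series" means these few. Any claim that something is new, unique, unknown or untested is made for them only; others in the source may bear on it.

Going by the values given here, compound 1 `CC1=C(/C=C/C(=O)/C=C/c2ccc(Br)cc2)C(C)(C)CCC1` gives 18900 nM in a functional assay on PC-3 cells (Homo sapiens) for cytotoxicity, read by sulforhodamine B assay, with a stated time of 48 h (on this read-out lower numbers stand for stronger inhibition and higher numbers for weaker inhibition), the lowest of the two numbers so far. Among the compounds with values here, compound 2 `COc1ccc(/C=C/C(=O)/C=C/C2=C(C)CCCC2(C)C)cc1` gives 58700 nM in this assay, and the step of a 3.1-fold higher number from compound 1 to compound 2 (0.49 log units; beyond the scatter) is the only measured step. Compound 3 `CC1=C(/C=C/C(=O)/C=C/c2ccoc2)C(C)(C)CCC1` differs from compound 1 by furan-3-yl in place of 4-bromophenyl on a double-bonded chain carbon bound to a double-bonded chain carbon. Within the data shown here, the one measured step exchanges only a group on the aromatic ring, whereas here the ring itself is exchanged, so it bears on the new step only loosely; a modest rise in the number is expected, of the size a 1.9-fold higher number from compound 1 to compound 3 (0.27 log units; within the scatter). For compound 3 the estimate is 35000 nM, with a range from 12000 nM to 100000 nM.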

Compound 3, half-maximal inhibitory concentration: 50300 nM
The estimate for compound 3 lay 1.4-fold (0.16 log units) below the measured number; the measured number falls inside the stated range.
By their numbers in this assay, from the lowest: compound 1; then compounds 3 and 2 (each within the scatter of the next).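

Exchanging the ring itself at this place, and not only a group on the ring, also raises the number in this assay, with a 2.7-fold higher number from compound 1 to compound 3 (0.43 log units; beyond the scatter) for furan-3-yl in place of 4-bromophenyl. Compound 1 therefore stays the lowest of the three, and compounds 3 and 2 lie within the scatter of each other. No evidence at hand accounts for this step.

Still open, from the compounds shown here alone, is whether another aromatic ring, such as pyridine or thiophene, would stay as close to compound 1. Going by these compounds, the effect of a carboxylic acid or a dimethylamino group on the phenyl ring is also open.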